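The compounds below may be only part of what the source reports. "The series", "measured", "known", "first", "only" and "open" are said of these compounds alone.

Compound 1 `O=C(O)c1csc([C@H]2CC[C@@H]3[C@@H](COc4cccc(Cl)c4)[C@H](O)C[C@@H]3O2)n1`: in an assay on HEK293 cells for agonist activity at prostaglandin E2 receptor EP2 subtype (Homo sapiens), read by a beta-galactosidase reporter and beta-arrestin recruitment, with a stated time of 90 min (a higher number here means that more compound is needed for the effect, a lower number that less compound is needed), compound 1 gives > 10000 nM, which is a limit of the assay and not a number.
Compound 2 `O=C(O)c1csc([C@H]2CC[C@@H]3[C@@H](COc4ccc(F)cc4)[C@H](O)C[C@@H]3O2)n1`: in this assay compound 2 gives > 10000 nM, again a limit.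
Compound 3 `Cc1cccc(OC[C@@H]2[C@H]3CC[C@H](c4nc(C(=O)O)cs4)O[C@H]3C[C@H]2O)c1`: in this assay compound 3 gives > 10000 nM, also a limit.

Compound 3 thus stands where every measured compound stands: the limit of > 10000 nM in this assay, at which 3 of the 3 values shown sit. The steps a step that the two limits leave unreadable from compound 1 to compound 2, a step that the two limits leave unreadable from compound 1 to compound 3 and a step that the two limits leave unreadable from compound 2 to compound 3 consequently have no readable size. Compound 4 `O=C(O)c1csc([C@H]2CC[C@@H]3[C@@H](COc4ccccc4C(F)(F)F)[C@H](O)C[C@@H]3O2)n1` differs from compound 3 by 2-(trifluoromethyl)phenyl in place of 3-methylphenyl on an oxygen on a saturated carbon. Among the compounds with values here, no measured step bears readably on this change, so no direction beyond the scatter can be read, and the step that the limit leaves unreadable from compound 3 to compound 4 is expected to stay small. Compound 4 is therefore estimated at 15000 nM, with a range from 4000 nM to 60000 nM, and is expected most likely to be reported again only as a limit.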

Compound 4, half-maximal effective concentration: 11 nM
The estimate for compound 4 lay 1400-fold (3.13 log units) above the measured number; measured number below the stated range.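

In this assay, the group on this oxygen proves able to change the result greatly: 2-(trifluoromethyl)phenyl gives an at least 900-fold lower number from compound 3 to compound 4 (2.95 log units; beyond the scatter), an at least 900-fold lower number from compound 2 to compound 4 (2.95 log units; beyond the scatter) and an at least 900-fold lower number from compound 1 to compound 4 (2.95 log units; beyond the scatter). The steps among compound 1, compound 2 and compound 3 cannot be read, so those compounds alone could not show this. Compound 4 is the only compound shown with a number rather than a limit: the limit of > 10000 nM in this assay, at which 3 of the 4 values shown sit.

From the compounds shown here alone, what remains open is whether the gain needs the trifluoromethyl group itself or its place on the ring. A 2-methylphenyl or a 3-(trifluoromethyl)phenyl group would separate these two possibilities.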